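Moving the acid and adding chlorine on the aryl ether

This account rests on a few compounds, and the source may have more. Where it says the series, first, only, none or still open, it means among the compounds named here.

Of the compounds shown here, two of a shared core have been measured in an assay on HEK293 cells for positive allosteric modulation of metabotropic glutamate receptor 2 (Rattus norvegicus), read by thallium flux, with a stated time of 2.5 min; a lower number here means that less compound is needed, a higher number that more compound is needed for the effect. Compound 1 `Cc1c(OCCCCOc2ccc(C(=O)O)cc2Cl)ccc(C(=O)CC2CCCC2)c1O` gives 237 nM in this assay. Compound 2 `Cc1c(OCCCCOc2ccccc2C(=O)O)ccc(C(=O)CC(C)C)c1O` gives 415 nM in this assay. Compound 2 has the highest of the two numbers, but its nearest neighbour, compound 1, lies within the scatter of it, so the two values cannot be told apart.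

Compound 3 `Cc1c(OCCCCOc2ccc(C(=O)O)c(Cl)c2)ccc(C(=O)CC(C)C)c1O` has not yet been measured. It differs from compound 2 in one place: 4-carboxy-3-chlorophenyl in place of 2-carboxyphenyl on an oxygen on a saturated carbon. Within the data shown here, no step between measured compounds exists for this change, so no measured size can be borrowed. Compound 1 also carries a carboxy group and a chlorine on the aryl ring at the end of the four-carbon chain, and its value sits close to that of compound 2, which gives no sign of a large shift.

For compound 3 the step from compound 2 is therefore expected to stay within the scatter, a 1.2-fold lower number from compound 2 to compound 3 (0.07 log units; within the scatter). Compound 3 is estimated at 350 nM in this assay, with a range from 120 nM to 1000 nM.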

Compound 3, half-maximal effective concentration: 151 nM
The estimate for compound 3 lay 2.3-fold (0.37 log units) above the measured number, and the stated range covers the measured number.
By their numbers in this assay, from the lowest: compounds 3, 1 and 2 (each within the scatter of the next, the first and the last beyond it).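

In this assay, putting 4-carboxy-3-chlorophenyl in place of 2-carboxyphenyl on an oxygen on a saturated carbon gives a 2.7-fold lower number from compound 2 to compound 3 (0.44 log units; beyond the scatter), a modest step but one beyond the scatter. This shows that the aryl group at this position can shift the number in this series, and that this change lowers it with the rest of the molecule held constant. The step carries two differences at once, a new place for the carboxy group and an added chlorine, and nothing here gives a reason for the shift or divides it between them.

Going by these compounds, what remains open is how much of the step belongs to each difference; 4-carboxyphenyl, which keeps the new place of the carboxy group but has no chlorine, would separate the two on this same core. Likewise, a fluorine or a methyl in place of the chlorine, or a primary amide in place of the carboxylic acid, would test whether the lower number depends on those particular atoms.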